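Pyrazole swap on the shared core: chloro-methyl to methyl-oxetanyl

The compounds below may be only part of what the source reports. "The series", "measured", "known", "first", "only" and "open" are said of these compounds alone.

Two compounds of the series have numbers in an assay on HEK293 cells for inhibition of Leucine-rich repeat serine/threonine-protein kinase 2 (Homo sapiens), with a stated time of 48 h; a lower number here means a stronger inhibitor, a higher number a weaker inhibitor. Compound 1 `Cc1c(Nc2nc(N)c3c(C#N)c(N4CCC[C@H]4C)n(C)c3n2)cnn1CC1(O)COC1` gives 220 nM in this assay. Compound 2 `C[C@@H]1CCCN1c1c(C#N)c2c(N)nc(Nc3cn(C)nc3Cl)nc2n1C` gives 190 nM in this assay. The two values lie within the scatter of each other, so neither compound can be set ahead of the other; compound 2 simply carries the smaller of the two numbers by a margin that means nothing.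

Compound 3 `Cc1c(Nc2nc(N)c3c(C#N)c(N4CCC[C@H]4C)n(C)c3n2)cnn1C1COC1` is not yet measured. It differs from compound 2 in one place: 5-methyl-1-(oxetan-3-yl)-1H-pyrazol-4-yl in place of 3-chloro-1-methyl-1H-pyrazol-4-yl on a nitrogen on an aromatic ring. Compound 1 already carries a pyrazole substituted with a methyl and an oxetane-bearing group at the same nitrogen, and its value sits beside that of compound 2, which suggests this region tolerates such exchanges without a large shift. Among the measured compounds shown here, no measured pair isolates this exact change, so the expectation rests on that comparison alone.

The step from compound 2 to compound 3 in this assay is expected to be a 1.2-fold higher number from compound 2 to compound 3 (0.06 log units; within the scatter), that is, no step beyond the scatter in either direction. For compound 3 the expected value in this assay is 220 nM, with a plausible range from 100 nM to 500 nM.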

Compound 3, half-maximal inhibitory concentration: 300 nM
Compound 3: the middle estimate sits 1.4-fold (0.13 log units) below what was measured; low and high end bracket the measured number.
By their numbers in this assay, from the lowest: compounds 2, 1 and 3 (each within the scatter of the next).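

In this assay the exchange of 3-chloro-1-methyl-1H-pyrazol-4-yl for 5-methyl-1-(oxetan-3-yl)-1H-pyrazol-4-yl on a nitrogen on an aromatic ring now has a direct reading of a 1.6-fold higher number from compound 2 to compound 3 (0.20 log units; within the scatter) and so shows that this position accepts the oxetane-bearing pyrazole with no step beyond the scatter. The series also gains a comparison within the oxetane-bearing pyrazoles: oxetan-3-yl in place of (3-hydroxyoxetan-3-yl)methyl on an aromatic nitrogen gives a 1.4-fold higher number from compound 1 to compound 3 (0.13 log units; within the scatter) and leaves the two groups indistinguishable in this assay. Nothing available bears on the reason for either reading.

The exchange between compound 2 and compound 3 alters the chlorine, the methyl and the oxetane together, so the contribution of each remains unresolved, and a pyrazole carrying chlorine together with oxetan-3-yl would be needed to separate them. Also open, from the compounds shown here alone, is whether this tolerance extends to other kinds of group on the pyrazole nitrogen, such as an amine or a carboxylic acid, or is confined to the methyl and oxetane-bearing groups seen so far.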